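The compounds below may be only part of what the source reports. "The series", "measured", "known", "first", "only" and "open" are said of these compounds alone.

Values in a functional assay on cells (Homo sapiens) for antiproliferative activity, read by MTT assay, with a stated time of 48 h; a higher number here means a weaker inhibitor, a lower number a stronger inhibitor:
- compound 1 `Cn1c(N)c(-c2nc3ccccc3[nH]2)c2nc(C#N)c(C#N)nc21`: > 50000 nM, a limit of the assay, not a number
- compound 2 `N#Cc1nc2c(-c3nc4ccccc4[nH]3)c(N)n(CCO)c2nc1C#N`: > 50000 nM, a limit of the assay, not a number
- compound 3 `CN1CCN(CCCn2c(N)c(-c3nc4ccccc4[nH]3)c3nc(C#N)c(C#N)nc32)CC1`: 4520 nM

Compound 3 is the only one of the three with a true number, while the other two stand at the limit of > 50000 nM in this assay, at which 2 of the 3 values shown sit. The next compound, compound 4 `N#Cc1nc2c(-c3nc4ccccc4[nH]3)c(N)n(CCCN3CCCCC3)c2nc1C#N`, keeps the shared core and changes one group: piperidin-1-yl in place of 4-methylpiperazin-1-yl, on a saturated chain carbon, three bonds along the chain from an aromatic nitrogen (piperidin-1-yl in place of 4-methylpiperazin-1-yl on a saturated chain carbon, three bonds along the chain from an aromatic nitrogen).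

Within the data shown here, two measured steps bear on this, both only indirectly. The first is an at least 11-fold lower number from compound 1 to compound 3 (1.04 log units; beyond the scatter). The second is an at least 11-fold lower number from compound 2 to compound 3 (1.04 log units; beyond the scatter). Among the measured compounds shown here, both are large, and both end at the only measured compound with a ring on its chain. Compound 4 keeps a ring at that place, so it is expected to stay close to compound 3 rather than fall back to the limit. For the measured compounds named here, no measured step swaps one of these rings for the other, so no direction can be argued, and a step within the scatter is expected in this assay. The expected step is a 1.1-fold lower number from compound 3 to compound 4 (0.05 log units; within the scatter). For compound 4 the estimated value is 4000 nM. For compound 4 the expected range runs from 1500 nM to 12000 nM.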

Compound 4, half-maximal inhibitory concentration: 6230 nM
Compound 4: the middle estimate sits 1.6-fold (0.19 log units) below what was measured, within the range that was stated.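

In this assay, piperidin-1-yl in place of 4-methylpiperazin-1-yl, on a saturated chain carbon, three bonds along the chain from an aromatic nitrogen, gives a 1.4-fold higher number from compound 3 to compound 4 (0.14 log units; within the scatter). That step lies within the scatter, so this assay does not tell the two rings apart, even though piperidin-1-yl holds one hetero atom where 4-methylpiperazin-1-yl holds two. With a second ring at the end of the propyl chain, the contrast with the compounds that lack one now rests on two compounds, seen in an at least 8.0-fold lower number from compound 2 to compound 4 (0.90 log units; beyond the scatter) and in an at least 8.0-fold lower number from compound 1 to compound 4 (0.90 log units; beyond the scatter), and both of these steps start from a limit of the assay rather than a number: the limit of > 50000 nM in this assay, at which 2 of the 4 values shown sit.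

The compounds shown leave open whether a ring is needed at all, or whether an open-chain amine such as dimethylamino on the same propyl chain would serve as well, and a morpholine ring would extend the comparison of rings. They also leave open how much the chain length matters, as both numbers come from a propyl chain, and a butyl chain ending in piperidin-1-yl would address that.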